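A few compounds are considered here, and "the series" means these few. Any claim that something is new, unique, unknown or untested is made for them only; others in the source may bear on it.

Measured so far:
compound 1 `CC(C)(C)c1cc2[nH]nc(N)c2c(=O)[nH]1`: 65%
compound 2 `CC(C)(C)c1cc2nn(-c3ccccc3)c(N)c2c(=O)[nH]1`: -1%

In an assay on isolated protein for inhibition of ribosomal protein S6 kinase alpha-5 (Homo sapiens), read by mobility shift assay, tested at 30 uM (a lower number here means less inhibition, a higher number more inhibition at the concentration tested (going by the name of the read-out)), compound 1 gives 65%, while compound 2 gives -1%, the lowest of the two numbers and beyond the scatter from compound 1. Compound 3 `COc1ccc(-c2cc3nn(-c4ccccc4)c(N)c3c(=O)[nH]2)cc1` is not yet measured; it differs from compound 2 by 4-methoxyphenyl in place of tert-butyl on an aromatic carbon and is otherwise the same. Among the compounds with values here, no measured step covers this change, so the step of a number 6 percentage points higher from compound 2 to compound 3 (within the scatter) is expected to be small, within the scatter, with no clear direction. Within the data shown here, the only anchor is compound 2, which shows essentially no inhibition. Compound 3 is therefore expected to give 5%, in the range -10% to 25%.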

Compound 3, a percentage reported as inhibition, at one concentration (the size of the read-out at that concentration, not a potency): 6%
Beside the measured number, compound 3's estimate is 1 percentage points below it; the measured number falls inside the stated range.
By their numbers in this assay, from the lowest: compounds 2 and 3 (each within the scatter of the next); then compound 1.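

On the aromatic carbon next to the ring nitrogen, putting 4-methoxyphenyl in place of tert-butyl gives, in this assay, a number 7 percentage points higher from compound 2 to compound 3 (within the scatter). Inhibition is close to nil in compound 2, so the step shows only that this exchange brings none back on this background, and it says little about the position where inhibition is present. Nothing available explains the small size of this step.

Still open, as far as these compounds go, is whether the same exchange would matter with the ring nitrogen unsubstituted, as in compound 1, and whether an amine or a carboxylic acid on this aromatic carbon would behave differently.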